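Adding a sulfonyl group to the ring nitrogen of compound 3

The source may hold more compounds than are shown below. What is called first, only, known or untested is meant among the compounds shown, and "the series" means these compounds.

In a functional assay on HepG2 cells (Homo sapiens) for cytotoxicity, read by MTT assay, with a stated time of 24 h (on this read-out lower numbers stand for stronger inhibition and higher numbers for weaker inhibition), compound 1 `CN1C/C(=C\c2ccncc2)C(=O)/C(=C/c2ccc(C#N)cc2)C1` gives 13900 nM, compound 2 `O=C1/C(=C/c2cccnc2)CNC/C1=C\c1ccccc1F` gives 21000 nM and compound 3 `O=C1/C(=C/c2cccnc2)CNC/C1=C\c1ccccc1C(F)(F)F` gives 5020 nM. Compound 3 therefore has the lowest of the three numbers, and its gaps to both other compounds lie beyond the scatter.

The next compound is compound 4 `O=C1/C(=C/c2cccnc2)CN(S(=O)(=O)c2ccc(F)cc2)C/C1=C\c1ccccc1C(F)(F)F`, with the change ((4-fluorophenyl)sulfonyl in place of hydrogen on an amine nitrogen in a ring). This places (4-fluorophenyl)sulfonyl in place of hydrogen on an amine nitrogen in a ring.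

Going by the values given here, the only measured step between compounds differing in one place is a 4.2-fold lower number from compound 2 to compound 3 (0.62 log units; beyond the scatter), with trifluoromethyl in place of fluoro on an aromatic carbon. That step is modest, but it concerns a different site, so it gives a rough scale and no direct guide to the direction at the nitrogen. Compound 1 differs from compound 3 in more than one place and isolates nothing about that nitrogen.

Among the compounds with values here, no measured step covers this change, so only a modest move towards a lower number in this assay is expected, on thin support, and a move the other way remains possible. The estimated step is a 1.7-fold lower number from compound 3 to compound 4 (0.22 log units; within the scatter). For compound 4 the expected value is 3000 nM, with an estimated range of 900 nM to 10000 nM.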

Compound 4, half-maximal inhibitory concentration: 2340 nM
Beside the measured number, compound 4's estimate is 1.3-fold (0.11 log units) above it, within the range that was stated.
By their numbers in this assay, from the lowest: compound 4; then compound 3; then compounds 1 and 2 (each within the scatter of the next).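

In this assay, going by these compounds alone, (4-fluorophenyl)sulfonyl in place of hydrogen on the amine nitrogen in the ring gives a 2.1-fold lower number from compound 3 to compound 4 (0.33 log units; beyond the scatter), the first reading at this position; the earlier step concerned a substituent on an aromatic carbon and said nothing about this nitrogen. The step is modest but beyond the scatter, so in this pair the hydrogen on that nitrogen is not needed to keep the number low, and a substituent carrying a six-membered aromatic ring is accepted there with a lower number, not a higher one. No measurement at hand accounts for this shift.

With one pair at this nitrogen, the step cannot be divided between the sulfonyl link and the 4-fluorophenyl ring, and a comparison with methanesulfonyl, unsubstituted phenylsulfonyl, acetyl or benzyl on the same nitrogen would be needed to separate them. Going by these compounds, it also remains open whether the same change gives a similar step when the trifluoromethyl of compound 3 is replaced by the fluoro of compound 2, or whether it holds with a morpholine or a carboxylic acid on the sulfonyl aryl ring.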